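Methoxy to bromo swap in a cytotoxicity series

A few compounds are considered here, and "the series" means these few. Any claim that something is new, unique, unknown or untested is made for them only; others in the source may bear on it.

Measured compounds:
Compound 1, `COc1cccc(-c2cnc(NC(=O)c3ccc(F)cc3)n2C)c1`: in a toxicity assay on THP-1 cells (Homo sapiens) for inhibition (on this read-out lower numbers stand for higher toxicity in this test and higher numbers for lower toxicity in this test), compound 1 gives > 100000 nM, which is a limit of the assay and not a number.
Compound 2, `COc1ccc(-c2cnc(NC(=O)c3ccc(C)cc3)n2C)cc1`: in this assay compound 2 gives > 100000 nM, again a limit and not a number.

Compound 1 thus stands at the limit, where both shown values sit: the limit of > 100000 nM in this assay, at which 2 of the 2 values shown sit. Going by the values given here, with both measured values being limits, no step between compound 1 and compound 2 can be read, and no measured step exists for the change that follows.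

Compound 3, `Cn1c(-c2cccc(Br)c2)cnc1NC(=O)c1ccc(F)cc1`, is not yet measured. It differs from compound 1 by bromo in place of methoxy on an aromatic carbon. Because compound 1 sits at the limit (the limit of > 100000 nM in this assay, at which 2 of the 2 values shown sit), no change beyond the scatter is expected, and the step from compound 1 to compound 3 is estimated as a step that the limit leaves unreadable from compound 1 to compound 3. Compound 3 is therefore expected near 120000 nM, in the range 30000 nM to 400000 nM, with a fair chance that only a limit is reported.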

Compound 3, half-maximal cytotoxic concentration: > 50000 nM
Compound 3: a limit, no number; the forecaster's own chance of this, stated with the estimate: 70%; the middle value is on the limit's open side.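

In this assay compound 3 gives > 50000 nM, a limit of the assay and not a number. Going by these compounds alone, compound 1 gives > 100000 nM, also a limit, so no step between compound 1 and compound 3 can be read. The compounds shown leave open how bromo and methoxy compare at this place, since none of them has a value that is a number.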